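Pyridin-3-yl for pyrrolidin-2-yl in a series at the limit

A few compounds are considered here, and "the series" means these few. Any claim that something is new, unique, unknown or untested is made for them only; others in the source may bear on it.

Measured so far in a functional assay on PC-3 cells (Homo sapiens) for antiproliferative activity, read by MTT assay, with a stated time of 24 h (on this read-out lower numbers stand for stronger inhibition and higher numbers for weaker inhibition), each value a limit of the assay:
- compound 1 `COc1ccc(-c2noc(C3CCCN3)n2)cc1OC1CCCC1` gives > 1000000 nM
- compound 2 `COc1ccc(-c2noc(Cc3c[nH]c4ccccc34)n2)cc1OC1CCCC1` gives > 1000000 nM
- compound 3 `COc1cc(-c2noc(-c3ccncc3)n2)ccc1OCc1ccccc1` gives > 1000000 nM

Compound 1 has no numerical value to stand on: its reading of > 1000000 nM is a limit. Among the measured compounds shown here, the same holds across the set, which shows the limit of > 1000000 nM in this assay, at which 3 of the 3 values shown sit, and offers no measured step to scale from.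

Next in line is compound 4 `COc1ccc(-c2noc(-c3cccnc3)n2)cc1OC1CCCC1`, with pyridin-3-yl in place of pyrrolidin-2-yl on an aromatic carbon of the shared core. The change counts as pyridin-3-yl in place of pyrrolidin-2-yl on an aromatic carbon and leaves the rest of the core of compound 1 as it is.

Because the limit of > 1000000 nM in this assay, at which 3 of the 3 values shown sit, the series gives little ground for predicting a large gain in this assay here. The expected step of an at least 1.6-fold lower number from compound 1 to compound 4 (0.22 log units; that floor lies within the scatter) is small and towards stronger inhibition, and a reading at the same limit remains likely. For compound 4 the estimated value is 600000 nM, within an expected range of 100000 nM to 1000000 nM for now.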

Compound 4, half-maximal inhibitory concentration: > 1000000 nM
Compound 4: no number, only a limit (the forecaster's own chance of this, stated with the estimate: 60%); middle value at least 1.6-fold (0.22 log units) away from the limit.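

Among the compounds shown here, compound 1 and compound 4 both read only as limits, so no step between them can be read in this assay: the limit of > 1000000 nM in this assay, at which 4 of the 4 values shown sit. The compounds shown leave open whether any change on the shared core gives a measurable value in this assay.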